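This account rests on a few compounds, and the source may have more. Where it says the series, first, only, none or still open, it means among the compounds named here.

Series notes. In an assay on isolated protein for binding affinity to Oxytocin receptor (Homo sapiens) (a higher number here means a weaker inhibitor, a lower number a stronger inhibitor), compound 3 `Cc1nc([C@H](C(=O)NC(C)C)N2C(=O)[C@@H](C3Cc4ccccc4C3)NC(=O)[C@H]2CC(C)C)co1` gives 1.26 nM, the lowest of the three numbers, though all three lie within the scatter of one another: compound 2 `CC(C)C[C@@H]1C(=O)N[C@H](C2Cc3ccccc3C2)C(=O)N1[C@@H](C(=O)NC(C)C)c1ccc(Br)s1` gives 2 nM and compound 1 `CC(C)C[C@@H]1C(=O)N[C@H](C2Cc3ccccc3C2)C(=O)N1[C@@H](C(=O)NC(C)C)c1ccc(-c2ccccn2)s1` gives 2.51 nM, with steps a 2.0-fold lower number from compound 1 to compound 3 (0.30 log units; within the scatter), a 1.6-fold lower number from compound 2 to compound 3 (0.20 log units; within the scatter) and a 1.3-fold lower number from compound 1 to compound 2 (0.10 log units; within the scatter). Compound 4 `Cc1nc([C@H](C(=O)N2CCC2)N2C(=O)[C@@H](C3Cc4ccccc4C3)NC(=O)[C@H]2CC(C)C)co1` is the next step: azetidin-1-yl in place of isopropylamino on a carbonyl carbon. For the measured compounds named here, none of the measured steps touches the amide end; all three vary the group on the saturated chain carbon bound to the ring nitrogen and the carbonyl carbon, and none leaves the scatter. Going by the values given here, no measured step bears on the change, so no movement beyond the scatter in this assay is expected for compound 4. Compound 4 is estimated at 1.6 nM (range 0.5 nM to 5 nM), an expected step of a 1.3-fold higher number from compound 3 to compound 4 (0.10 log units; within the scatter).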

Compound 4, inhibition constant: 1.59 nM
Estimate against measurement, compound 4: 1.0-fold (0.00 log units) above, and the stated range covers the measured number.
By their numbers in this assay, from the lowest: compounds 3, 4, 2 and 1 (each within the scatter of the next).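

In this assay the amide end now has a measured change, and a 1.3-fold higher number from compound 3 to compound 4 (0.10 log units; within the scatter) for azetidin-1-yl in place of isopropylamino on a carbonyl carbon stays within the scatter. The amide hydrogen can therefore be lost and the group closed into a four-membered ring without the number moving beyond the scatter. No available evidence gives a reason for this result.

Still open, going by these compounds, is whether a larger ring such as piperidin-1-yl, a longer chain on the amide nitrogen, or a carboxylic acid at this carbonyl carbon would stay within the scatter. Also open, on these data alone, is whether azetidin-1-yl behaves alike with 5-bromothiophen-2-yl in place of 2-methyl-1,3-oxazol-4-yl.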